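Notes on the triazole-to-amide swap at the benzylic carbon

The compounds below may be only part of what the source reports. "The series", "measured", "known", "first", "only" and "open" are said of these compounds alone.

Measured so far:
Compound 1, `CC(C)C(Nc1nnc[nH]1)c1ccc(-c2ccc3cccc(F)c3c2)[nH]c1=O`: in an ADME assay on microsomes from liver (Homo sapiens) for metabolic stability (a lower number here means that the compound disappears faster, a higher number that the compound lasts longer), compound 1 gives > 3 h, which is a limit of the assay rather than a number.
Compound 2, `CCn1ncc2c(F)cc(-c3ccc(C(CC)(CC)c4nnc[nH]4)c(=O)[nH]3)cc21`: in this assay compound 2 gives 2.7 h.
Compound 3, `CCn1ncc2c(F)cc(-c3ccc(C(CC)(CC)c4ncn(C)n4)c(=O)[nH]3)cc21`: in this assay compound 3 gives > 3 h, again a limit of the assay.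

Compound 1 therefore stands at the upper edge of what the assay reports, where (the limit of > 3 h in this assay, at which 2 of the 3 values shown sit); its true half-life is not known beyond that. For the measured compounds named here, the one measured step, an at least 1.1-fold higher number from compound 2 to compound 3 (0.04 log units; that floor lies within the scatter), is within the scatter, and it concerns 1-methyl-1H-1,2,4-triazol-3-yl in place of 4H-1,2,4-triazol-3-yl on a different position and a different core from the change now at hand, so it does not bear on it directly.

Compound 4, `CC(C)NC(=O)CC(c1ccc(-c2ccc3cccc(F)c3c2)[nH]c1=O)C(C)C`, keeps the core of compound 1 and differs as follows: (isopropylcarbamoyl)methyl in place of (4H-1,2,4-triazol-3-yl)amino on a saturated chain carbon bound to an aromatic carbon and a saturated chain carbon.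

Going by the values given here, no measured step tests this change, so the expectation rests on compound 1 alone. Compound 4 is expected to sit near the limit of compound 1 in this assay, with more room downward than upward, at 2.5 h (range 1 h to 3 h). The implied step, an at least 1.2-fold lower number from compound 1 to compound 4 (0.07 log units; that floor lies within the scatter), is expected to stay within the scatter or point slightly downward.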

Compound 4, half-life: 0.32 h
Compound 4: middle estimate off by 7.8-fold (0.89 log units), on the high side, and the stated range ends above it.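

At the saturated chain carbon bound to an aromatic carbon and a saturated chain carbon, the group matters for stability on an unchanged core: in this assay, (isopropylcarbamoyl)methyl in place of (4H-1,2,4-triazol-3-yl)amino gives an at least 9.3-fold lower number from compound 1 to compound 4 (0.97 log units; beyond the scatter). Compound 4 is the first compound shown with a half-life well clear of the top of the reported range, so this change opens a real difference where the earlier compounds offered only limits and a value close to them. Compound 1 is a limit of the assay, so the step is only a floor and its full size stays unknown: the limit of > 3 h in this assay, at which 2 of the 4 values shown sit.

The compounds shown leave open which part of the change carries the drop: the loss of the five-membered aromatic ring, the loss of the amino link, or the arrival of the isopropyl amide. A primary amide or a (4H-1,2,4-triazol-3-yl)methyl group in the same place would help to separate these parts, and the data at hand give no cause for the drop.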